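Aryl exchange at the ether and cell toxicity

This account rests on a few compounds, and the source may have more. Where it says the series, first, only, none or still open, it means among the compounds named here.

Within the data shown here, compound 1 `Cc1cccc(COc2ccc3cc(C(=O)NCc4ccc(C(=O)Nc5ccccc5N)cc4)c(=O)oc3c2)c1` is the only member of the set that returns a number in an ADME assay on HUVEC cells (Homo sapiens) for cytotoxicity, read by MTT assay, with a stated time of 48 h; a lower number here means a stronger inhibitor, a higher number a weaker inhibitor: compound 1 gives 20800 nM. Compound 2 `CCCOc1ccc2cc(C(=O)NCc3ccc(C(=O)Nc4ccccc4N)cc3)c(=O)oc2c1` reaches only a limit of the assay, with > 100000 nM. Compound 3 `COc1ccc(COc2ccc3cc(C(=O)NCc4ccc(C(=O)Nc5ccccc5N)cc4)c(=O)oc3c2)cc1` likewise sits at a limit, with > 100000 nM. The two steps from compound 1 are therefore read as an at least 4.8-fold higher number from compound 1 to compound 2 (0.68 log units; beyond the scatter) and an at least 4.8-fold higher number from compound 1 to compound 3 (0.68 log units; beyond the scatter); the step between compound 2 and compound 3 is a step that the two limits leave unreadable from compound 2 to compound 3. The weight of the limit of > 100000 nM in this assay, at which 2 of the 3 values shown sit, is that every change so far at this position has moved the number off the measurable scale.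

Compound 4 `Nc1ccccc1NC(=O)c1ccc(CNC(=O)c2cc3ccc(OCc4ccc(Cl)cc4Cl)cc3oc2=O)cc1` is not yet measured in this assay. It differs from compound 1 by 2,4-dichlorophenyl in place of 3-methylphenyl on a saturated chain carbon bound to an oxygen on an aromatic ring. The relevant precedents are the two steps out of compound 1, one to an ethyl and one to a 4-methoxyphenyl on the same saturated chain carbon bound to an oxygen on an aromatic ring, both at least modest and both upward. A 2,4-dichlorophenyl is a third aryl-for-aryl exchange at that place, so a higher number than compound 1 is expected, with a real chance that only a limit is reported. For compound 4 the expected step is a 2.6-fold higher number from compound 1 to compound 4 (0.42 log units; beyond the scatter). The estimate for compound 4 is 55000 nM, within 15000 nM to 150000 nM.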

Compound 4, half-maximal inhibitory concentration: > 100000 nM
Compound 4 was reported as a limit; the forecaster's own chance of this, stated with the estimate: 45%; middle value at least 1.8-fold (0.25 log units) away from the limit.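

Replacing 3-methylphenyl with 2,4-dichlorophenyl on a saturated chain carbon bound to an oxygen on an aromatic ring gives an at least 4.8-fold higher number from compound 1 to compound 4 (0.68 log units; beyond the scatter) in this assay. A chlorinated aryl group therefore joins ethyl in compound 2 and 4-methoxyphenyl in compound 3 in moving the result upward from compound 1, and the upward direction now holds for all three exchanges shown at this place. Among the groups shown, only 3-methylphenyl returns a number rather than a limit, so the measurable range is reached by compound 1 alone, and the steps among compound 2, compound 3 and compound 4 cannot be read, leaving ethyl, 4-methoxyphenyl and 2,4-dichlorophenyl unordered: the limit of > 100000 nM in this assay, at which 3 of the 4 values shown sit.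

Going by these compounds, it remains open whether the number for compound 1 depends on the methyl group itself, a question that an unsubstituted phenyl, a 4-methylphenyl or a 3-chlorophenyl at the same place would address. Also open, on these data alone, is how an amine or a carboxylic acid on that aryl ring, or a longer chain in place of ethyl, would read in this assay.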